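A few compounds are considered here, and "the series" means these few. Any claim that something is new, unique, unknown or untested is made for them only; others in the source may bear on it.

Working notes on the series.

Four compounds share a carbamate-amide arrangement and are compared in a physicochemical assay for lipophilicity; on this read-out higher numbers stand for higher lipophilicity and lower numbers for lower lipophilicity. Compound 1 is `CCCCCCCNC(=O)Oc1ccc(Cl)cc1C(=O)Nc1cccc(Cl)c1`; compound 2 is `CCCCCCCCNC(=O)Oc1ccc(Cl)cc1C(=O)Nc1cccc(Cl)c1`; compound 3 is `CCCCCNC(=O)Oc1ccc(Cl)cc1C(=O)Nc1ccc(Cl)cc1`; compound 4, not yet measured, is `CCCCCCNC(=O)Oc1ccc(Cl)cc1C(=O)Nc1ccc(Cl)cc1`.

In this assay compound 1 gives 5.94, and compound 2 gives 6.36. The change between them is methyl in place of hydrogen on a saturated chain carbon, seven bonds along the chain from an amide-type nitrogen, and the step it made, a number 0.42 log units higher from compound 1 to compound 2 (beyond the scatter), lies beyond the scatter. In this assay, going by the values given here, compound 3 gives 5.11, the lowest of the three numbers measured so far. How the core of compound 3 differs from the core of compound 1 is not broken down here.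

Compound 4 relates to compound 3 by methyl in place of hydrogen on a saturated chain carbon, five bonds along the chain from an amide-type nitrogen. Among the compounds with values here, this is the same kind of change as the one from compound 1 to compound 2, but not the same: there the methyl enters seven bonds along the chain from an amide-type nitrogen, here five bonds along the chain from an amide-type nitrogen. In this assay, one measured step of this kind is available, so the expectation rests on it alone; the step from compound 3 to compound 4 is expected to be a number 0.42 log units higher from compound 3 to compound 4 (beyond the scatter), close to the step seen from compound 1 to compound 2. Compound 4 is thus estimated at 5.53 in this assay, expected to fall between 5.25 and 5.85.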

Compound 4, partition coefficient: 5.53
The estimate for compound 4 equals the measured number at the digits printed; the range from low to high includes it.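

In this assay the added methyl gives a number 0.42 log units higher from compound 3 to compound 4 (beyond the scatter) on the core of compound 3, and that step matches at the printed digits a number 0.42 log units higher from compound 1 to compound 2 (beyond the scatter) on the core of compound 1. For these two pairs, then, the change carries from one core to the other with its size intact, although the methyl enters five bonds along the chain from an amide-type nitrogen in one pair and seven bonds along in the other. Two pairs do not establish a rule for the series, and they differ in both core and place of the change, so the agreement cannot be assigned to either alone; nothing measured here bears on why the two steps agree.

The compounds shown leave open whether a step of this size would persist with a longer chain, or with an amine or a carboxylic acid entering in place of the methyl. They also leave open whether the same change would hold on any core other than these two, including at other places along the chain.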